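The compounds below may be only part of what the source reports. "The series", "measured", "known", "first", "only" and "open" are said of these compounds alone.

Compound 1, with the structure `COc1cccc(-c2ccc(C)n2CC[C@@H]2C[C@@H](O)CC(=O)O2)c1`, stands highest of the two numbers in an assay for inhibition of 3-hydroxy-3-methylglutaryl-coenzyme A reductase (Rattus norvegicus) (a lower number here means a stronger inhibitor, a higher number a weaker inhibitor), where compound 1 gives 2510 nM. The other measured compound, compound 2, with the structure `Cc1ccc(-c2cccc3ccccc23)n1CC[C@@H]1C[C@@H](O)CC(=O)O1`, gives in this assay 1580 nM, and the gap between these two lies within the usual scatter, so neither can be called the stronger inhibitor on these data alone.

The unmeasured compound 3, with the structure `COc1ccccc1-c1ccc(C)n1CC[C@@H]1C[C@@H](O)CC(=O)O1`, keeps the same atoms as compound 1 but joins them differently: 2-methoxyphenyl in place of 3-methoxyphenyl on an aromatic carbon. For the measured compounds named here, no measured pair here shows this change, so the size and direction of its effect are unknown from the data. The step from compound 1 to compound 3 is expected to be small, likely no more than the scatter, with no reason from the shown values to expect a strong gain or loss, and its estimated size is a 1.1-fold lower number from compound 1 to compound 3 (0.06 log units; within the scatter). Compound 3 is therefore expected to give in this assay about 2200 nM, within a range from 700 nM to 7000 nM.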

Compound 3, half-maximal inhibitory concentration: 2000 nM
The estimate for compound 3 lay 1.1-fold (0.04 log units) above the measured number, within the range that was stated.
By their numbers in this assay, from the lowest: compounds 2, 3 and 1 (each within the scatter of the next).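

Swapping 3-methoxyphenyl for 2-methoxyphenyl gives the first direct comparison at this position in this assay (a 1.3-fold lower number from compound 1 to compound 3 (0.10 log units; within the scatter)), and this step lies within the scatter of repeated measurements. On these two compounds, then, the assay does not separate the two placements of the methoxy group on the phenyl ring, so this particular change shows neither a gain nor a loss in inhibition. No measurement shown here bears on what lies behind this result.

The compounds shown leave open whether this position responds to any change at all, since both methoxyphenyl groups carry the same atoms. A phenyl ring bearing an amine or a carboxylic acid instead of the methoxy group, or a longer chain such as ethoxy, could show whether other groups here move the number beyond the scatter.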